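Cyclopropane amide series: the ring-stereocentre epimer of compound 1

The source may report more compounds than this note shows. Statements on the series, on what has been measured and on what is new or still open speak of the compounds shown alone.

Measured compounds:
compound 1 `CCOC(=O)[C@]1(C(=O)Nc2ccccc2Cl)C[C@@H]1c1cc(OC)c(OC)c(OC)c1` — > 100000 nM
compound 2 `COc1cc([C@H]2C[C@@]2(CO)C(=O)Nc2ccccc2)cc(OC)c1OC` — > 100000 nM
compound 3 `CCOC(=O)C1(C(=O)NCc2ccccc2)CC1c1cc(OC)c(OC)c(OC)c1` — 46500 nM; 76300 nM (2 entries)

In a functional assay on HeLa cells (Homo sapiens) for cytotoxicity, read by MTT assay, with a stated time of 48 h (a lower number here means a stronger inhibitor, a higher number a weaker inhibitor), compound 1 gives > 100000 nM, which is a limit of the assay and not a number. Compound 2 gives > 100000 nM, also a limit. Among the compounds with values here, compound 3 is the only compound with a measured number, the repeated entries of compound 3 standing at 46500 nM; 76300 nM (2 entries) (the several entries of compound 3 in this assay, 46500 nM; 76300 nM (2 entries)). Compound 1 therefore sits at the limit of this assay, where two of the three shown values lie (the limit of > 100000 nM in this assay, at which 2 of the 3 values shown sit), so nothing more precise is known of where it stands.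

Within the data shown here, no pair of measured compounds that differ in a single place is available, so no measured step can be drawn on.

Compound 4 `CCOC(=O)[C@]1(C(=O)Nc2ccccc2Cl)C[C@H]1c1cc(OC)c(OC)c(OC)c1` differs from compound 1 in the following way: the two compounds have the same atoms and bonds and differ only in configuration as drawn: 1 of 2 stereo elements differ; a stereocentre at a saturated ring carbon is drawn R in compound 1 and S in compound 4. With no measured step of this kind in the series, the expectation in this assay is a change of no more than the scatter, a number no higher from compound 1 to compound 4 (the limit leaves the size open). Compound 4 is estimated at 100000 nM, with a range from 30000 nM to 300000 nM, and is most likely to be reported again only as a limit.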

Compound 4, half-maximal inhibitory concentration: 42400 nM
Compound 4: the middle estimate sits 2.4-fold (0.37 log units) above what was measured, within the range that was stated.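

Within the data shown here, the first measured step comes from the stereocentre at a saturated ring carbon, which in this assay gives an at least 2.3-fold lower number from compound 1 to compound 4 (0.37 log units; beyond the scatter) as the drawn configuration changes from R to S. For compound 1 the value > 100000 nM is a limit of the assay and not a number. No atom or bond changes in this pair, so the difference in the read-out belongs to configuration at this one position alone: the fact that compounds 1 and 4 differ only in the configuration as drawn.

As far as these compounds go, the full size of the step stays open, as does any effect of the second stereo element, which is the same in both compounds. Also open, from the compounds shown here alone, is whether the same change of configuration gives a step of this kind on a core carrying a carboxylic acid or an amine in place of the ethyl ester.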